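Moving the Fluorine to a Different Ring Carbon

The compounds below may be only part of what the source reports. "The series", "measured", "known", "first", "only" and "open" are said of these compounds alone.

In an assay on HEK293 cells for activation of Kir3.1/Kir3.2 (Homo sapiens), read by thallium flux (a lower number here means that less compound is needed, a higher number that more compound is needed for the effect), compound 1 `Cc1cc(NC(=O)Cn2nnc(-c3ccccc3)n2)n(C2CCCCC2)n1` gives 96 nM and compound 2 `Cc1cc(NC(=O)Cn2nnc(-c3ccccn3)n2)n(C2CCCCC2)n1` gives 14600 nM. Compound 3 `Cc1cc(NC(=O)Cn2nnc(-c3cccc(F)c3)n2)n(C2CCCCC2)n1` gives 81 nM in this assay, the lowest of the three numbers: a 1.2-fold lower number from compound 1 to compound 3 (0.07 log units; within the scatter), while a 180-fold lower number from compound 2 to compound 3 (2.26 log units; beyond the scatter). Compound 4 `Cc1cc(NC(=O)Cn2nnc(-c3ccccc3F)n2)n(C2CCCCC2)n1` keeps the same atoms and only shifts the fluorine: 2-fluorophenyl in place of 3-fluorophenyl on an aromatic carbon. Going by the values given here, two measured steps bear on this. The step of a 1.2-fold lower number from compound 1 to compound 3 (0.07 log units; within the scatter) shows that adding fluoro to this ring leaves the number within the scatter, whereas the step of a 150-fold higher number from compound 1 to compound 2 (2.18 log units; beyond the scatter) shows a large step only when the ring itself is swapped. Among the compounds with values here, no measured step moves a fluorine from one ring carbon to another, so a step within the scatter is expected in this assay, a 1.9-fold higher number from compound 3 to compound 4 (0.27 log units; within the scatter). Compound 4 is estimated at 150 nM, with a range from 50 nM to 500 nM.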

Compound 4, half-maximal effective concentration: 187 nM
Estimate against measurement, compound 4: 1.2-fold (0.10 log units) below, and the stated range covers the measured number.
By their numbers in this assay, from the lowest: compounds 3, 1 and 4 (each within the scatter of the next, the first and the last beyond it); then compound 2.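

Where the fluorine sits on the phenyl ring does register in this assay, with a 2.3-fold higher number from compound 3 to compound 4 (0.36 log units; beyond the scatter) as a modest step, something the earlier compounds could not show. The 2-fluorophenyl group still matches plain phenyl within the scatter, with a 1.9-fold higher number from compound 1 to compound 4 (0.29 log units; within the scatter) for that change, and it keeps most of the large gain over pyridin-2-yl, with a 78-fold lower number from compound 2 to compound 4 (1.89 log units; beyond the scatter) for the swap. Nothing available explains why the two fluorine positions differ.

The compounds shown leave open whether a chloro, methoxy or amine group on this phenyl ring would behave like fluoro.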